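The compounds below may be only part of what the source reports. "The series", "measured", "known", "first", "only" and "open" are said of these compounds alone.

Compound 1 `FC(F)(F)c1ccc(Nc2cc3[nH]c(-c4cccc(C(F)(F)F)c4)nc3cn2)nc1` was measured in a physicochemical assay for solubility, using the shake flask method, in simulated intestinal fluid, measured as kinetic solubility, with a stated time of 20 h, at pH 6.5; a lower number here means a less soluble compound, a higher number a more soluble compound. For compound 1 the result is a limit of the assay, >= 50000 nM, so compound 1 stands at the upper edge of what the numbers can show rather than at a fixed point. A companion, compound 2 `O=C(O)c1ccnc(Nc2cc3[nH]c(-c4cccc(C(F)(F)F)c4)nc3cn2)c1`, gives 60000 nM in this assay. The step that the limit leaves unreadable from compound 1 to compound 2 cannot be sized because the limit of >= 50000 nM in this assay, at which 1 of the 2 values shown sits, places compound 1 on a boundary, not a number.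

Compound 3 `FC1(F)CC(c2nc3cnc(Nc4ccc(C(F)(F)F)cn4)cc3[nH]2)C1` has not yet been measured. It differs from compound 1 in one place: 3,3-difluorocyclobutyl in place of 3-(trifluoromethyl)phenyl on an aromatic carbon. Among the measured compounds shown here, none of the measured steps touches this position; the only measured step alters the group on the ring nitrogen instead, and it is unreadable in any case. Nothing in the numbers therefore argues for a shift beyond the scatter, and the step from compound 1 to compound 3 is expected to be a step that the limit leaves unreadable from compound 1 to compound 3. Compound 3 is accordingly estimated to give 60000 nM in this assay, within a range from 25000 nM to 150000 nM, quite possibly reported again only as a limit.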

Compound 3, solubility: 161000 nM
For compound 3 the middle estimate is 2.7-fold (0.43 log units) below the measured one; the measured number lies above the stated range.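

In this assay compound 1 gives >= 50000 nM, which is a limit of the assay and not a number. The step from compound 1 to compound 3 therefore cannot be read, because it would have to start from that limit: the limit of >= 50000 nM in this assay, at which 1 of the 3 values shown sits.

Still open, as far as these compounds go, is how the solubility of compound 3 truly compares with that of compound 1, whose exact value remains unknown.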